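Swapping the amine on the dithiocarbamate of compound 1

The compounds below may be only part of what the source reports. "The series", "measured", "known", "first", "only" and "open" are said of these compounds alone.

The measured compounds and their values:
compound 1 `CN(Cc1cccnc1)C(=S)SCc1ccc(C(=O)Nc2ccccc2N)cc1` 83.8%
compound 2 `Nc1ccccc1NC(=O)c1ccc(CSC(=S)N2CCN(c3ccc(F)cc3)CC2)cc1` 76.3%
compound 3 `Nc1ccccc1NC(=O)c1ccc(CSC(=S)N2CCN(Cc3ccccc3)CC2)cc1` 29.3%

In a functional assay on A-375 cells (Homo sapiens) for antiproliferative activity, read by CCK-8 assay, with a stated time of 72 h, tested at 8 uM (a higher number here means a stronger effect of the compound at the concentration tested, a lower number a weaker effect), compound 1 gives 83.8%, the highest of the three numbers. Compound 2 gives 76.3%, which lies within the scatter of compound 1. Compound 3 gives 29.3%, well beyond the scatter below both. The only single-place step among these is a number 47 percentage points lower from compound 2 to compound 3 (beyond the scatter).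

Compound 4 `CN1CCN(C(=S)SCc2ccc(C(=O)Nc3ccccc3N)cc2)CC1` is not yet measured. It differs from compound 1 by 4-methylpiperazin-1-yl in place of methyl((pyridin-3-yl)methyl)amino on a thiocarbonyl carbon. Going by the values given here, no measured step touches this exact change. Among the compounds with values here, the one step that bears on it is a number 47 percentage points lower from compound 2 to compound 3 (beyond the scatter), where a group on the ring nitrogen that is not an aromatic ring went with a much weaker effect. Compound 4 also carries a small non-aromatic group on that nitrogen, so a large fall in this assay is expected, though less certain than a direct step would make it. The expected step is a number 48.8 percentage points lower from compound 1 to compound 4 (beyond the scatter), giving compound 4 an estimated 35% with a range from 10% to 70%.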

Compound 4, a percentage reported as inhibition, at one concentration (the size of the read-out at that concentration, not a potency): 91.6%
Compound 4: the middle estimate sits 56.6 percentage points below what was measured; measured number outside the range, above it.
By their numbers in this assay, from the lowest: compound 3; then compounds 2, 1 and 4 (each within the scatter of the next, the first and the last beyond it).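

On the thiocarbonyl carbon, 4-methylpiperazin-1-yl can stand in place of methyl((pyridin-3-yl)methyl)amino in this assay with a number 7.8 percentage points higher from compound 1 to compound 4 (within the scatter) and so the aromatic ring of compound 1 is not required for this effect. A non-aromatic group on the ring nitrogen is not a drawback in itself either: methyl in place of 4-fluorophenyl gives a number 15.3 percentage points higher from compound 2 to compound 4 (beyond the scatter) while methyl in place of benzyl gives a number 62.3 percentage points higher from compound 3 to compound 4 (beyond the scatter) so among these compounds the weak result goes with benzyl alone. Nothing measured here explains why benzyl and methyl differ so widely.

On these data alone, it remains open whether a slightly larger group on that nitrogen, such as ethyl or acetyl, would keep the effect. Also open, as far as these compounds go, is whether the second ring nitrogen matters at all, which morpholine in place of 4-methylpiperazin-1-yl could test.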